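A few compounds are considered here, and "the series" means these few. Any claim that something is new, unique, unknown or untested is made for them only; others in the source may bear on it.

Three compounds with a shared core are in hand. Compound 1 `O=C1NCCC12CCN(c1c(Cl)cncc1-c1ccoc1)CC2` gives 750 nM in a functional assay on MV4-11 cells (Homo sapiens) for inhibition, read by resazurin assay, with a stated time of 72 h; a higher number here means a weaker inhibitor of growth, a lower number a stronger inhibitor of growth; compound 2 `O=C1NCCC12CCN(c1c(Cl)cncc1-c1cccs1)CC2` gives 480 nM; compound 3 `Cc1csc(-c2cncc(Cl)c2N2CCC3(CCNC3=O)CC2)c1` gives 650 nM. Compound 2 holds the lowest of the three numbers, yet every step to it lies within the scatter: a 1.6-fold lower number from compound 1 to compound 2 (0.19 log units; within the scatter), and in the other sense a 1.4-fold higher number from compound 2 to compound 3 (0.13 log units; within the scatter).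

Compound 4 `O=Cc1cc(-c2cncc(Cl)c2N2CCC3(CCNC3=O)CC2)cs1` differs from compound 2 by 5-formylthiophen-3-yl in place of thiophen-2-yl on an aromatic carbon. Among the measured compounds shown here, the steps that bear on this are the exchanges of one five-membered ring for another, a 1.6-fold lower number from compound 1 to compound 2 (0.19 log units; within the scatter) and a 1.2-fold lower number from compound 1 to compound 3 (0.06 log units; within the scatter), and the added methyl, a 1.4-fold higher number from compound 2 to compound 3 (0.13 log units; within the scatter), none beyond the scatter. The 5-formylthiophen-3-yl group goes further than anything tried, so the range is kept wide, but no step beyond the scatter is expected in this assay. The expected step is a 1.3-fold higher number from compound 2 to compound 4 (0.10 log units; within the scatter). Compound 4 is estimated at 600 nM, between 250 nM and 1500 nM.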

Compound 4, concentration for 50% growth inhibition: 730 nM
Estimate against measurement, compound 4: 1.2-fold (0.09 log units) below; the range from low to high includes it.
By their numbers in this assay, from the lowest: compounds 2, 3, 4 and 1 (each within the scatter of the next).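

With 5-formylthiophen-3-yl on this aromatic carbon, ortho to a large group, all three comparisons in this assay stay within the scatter: a 1.5-fold higher number from compound 2 to compound 4 (0.18 log units; within the scatter), a 1.1-fold higher number from compound 3 to compound 4 (0.05 log units; within the scatter) and a 1.0-fold lower number from compound 1 to compound 4 (0.01 log units; within the scatter). The position therefore carries a formyl-bearing thiophene, as well as the unsubstituted and methyl-bearing five-membered rings, without a step beyond the scatter. No supporting data bear on this result.

Open, from the compounds shown here alone, is whether an amine or a carboxylic acid on the thiophene, or a phenyl ring in its place, would give a step beyond the scatter. Also open, going by these compounds, is what replacing the chloro group would do.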